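This account rests on a few compounds, and the source may have more. Where it says the series, first, only, none or still open, it means among the compounds named here.

Compound 1 `CCN(CC)Cc1cc(C)cc(Nc2nc3ccccc3n2Cc2ccc(C#N)cc2)c1O` is measured in an ADME assay on CHO cells (Cricetulus griseus) for inhibition, read by MTT assay (a higher number here means a weaker inhibitor, a lower number a stronger inhibitor), where compound 1 gives 14200 nM. Compound 3 `CCN(CC)Cc1cc(C)cc(Nc2nc3ccccc3n2Cc2ccc(F)cc2)c1O` is its partner, reached through (fluoro in place of cyano on an aromatic carbon), and in this assay compound 3 gives 18700 nM. The step of a 1.3-fold higher number from compound 1 to compound 3 (0.12 log units; within the scatter) is therefore a small one.

Compound 2 `CCN(CC)Cc1ccc(C)c(Nc2nc3ccccc3n2Cc2ccc(C#N)cc2)c1O` is built from the same atoms as compound 1 joined differently; the difference between the two cores is not broken down here. In this assay compound 2 gives only a limit, > 50000 nM, and no number. This is the limit of > 50000 nM in this assay, at which 1 of the 3 values shown sits.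

Compound 4 `CCN(CC)Cc1ccc(C)c(Nc2nc3ccccc3n2Cc2ccc(F)cc2)c1O` has not yet been measured in this assay. It differs from compound 2 by fluoro in place of cyano on an aromatic carbon, the same change that turns compound 1 into compound 3, with the place of the change described in identical words for both pairs. The pair of compound 2 and compound 4 is the second occurrence of this change among the compounds shown; the pair of compound 1 and compound 3 is the first.

Because a 1.3-fold higher number from compound 1 to compound 3 (0.12 log units; within the scatter) stayed within the scatter, compound 4 is expected to move by a step that the limit leaves unreadable from compound 2 to compound 4 in this assay. Compound 4 is accordingly estimated at 70000 nM, with a range from 30000 nM to 200000 nM, and a result that again comes back only as a limit is the expected outcome rather than a surprise.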

Compound 4, half-maximal inhibitory concentration: > 50000 nM
Compound 4: no number, only a limit (the forecaster's own chance of this, stated with the estimate: 75%); the middle value lies beyond the limit too.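

In this assay compound 4 gives only a limit, as compound 2 does, so no step between compound 2 and compound 4 can be read: the limit of > 50000 nM in this assay, at which 2 of the 4 values shown sit.

The compounds shown leave open whether fluoro in place of cyano changes the number on the core of compound 2, since neither compound on that core has a value beyond a limit.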